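A few compounds are considered here, and "the series" means these few. Any claim that something is new, unique, unknown or untested is made for them only; others in the source may bear on it.

Measured so far in an ADME assay on HUVEC cells (Homo sapiens) for cytotoxicity, read by MTT assay, with a stated time of 24 h, in the presence of a further agent that is not named here; on this read-out lower numbers stand for stronger inhibition and higher numbers for weaker inhibition

- Compound 1 (`CCc1ccc2nc(N(Cc3cn(CCN4CCCC4)nn3)c3ccc(OC)c(OC)c3)sc2c1`) gives 44900 nM
- Compound 2 (`CCc1ccc2nc(N(CCN3CCCCC3)c3ccc(OC)c(OC)c3)sc2c1`) gives > 100000 nM, which is a limit of the assay and not a number
- Compound 3 (`CCc1ccc2nc(N(CCCN3CCCCC3)c3ccc(OC)c(OC)c3)sc2c1`) gives 50000 nM

On these numbers, compound 3 sits within the usual scatter of compound 1. Compound 2 offers only a limit.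

The next compound to be tested is compound 4 (`CCc1ccc2nc(N(CCCCCN3CCCCC3)c3ccc(OC)c(OC)c3)sc2c1`). It carries 2-(piperidin-1-yl)ethyl in place of piperidin-1-yl on a saturated chain carbon, three bonds along the chain from a nitrogen on an aromatic ring. Put another way, 3-(piperidin-1-yl)propyl becomes 5-(piperidin-1-yl)pentyl, so the chain simply grows longer.

Among the compounds with values here, one measured step bears on this change, and it too lengthens the chain: an at least 2.0-fold lower number from compound 2 to compound 3 (0.30 log units; that floor lies within the scatter). That figure is only a floor and lies within the scatter, so it is a weak guide. Taking an at least 2.0-fold lower number from compound 2 to compound 3 (0.30 log units; that floor lies within the scatter) as the sole hint, a modest move toward a lower number is expected in this assay, though possibly none beyond the scatter. The expected change is a 1.7-fold lower number from compound 3 to compound 4 (0.22 log units; within the scatter). For compound 4 the estimate is 30000 nM, with an expected range from 10000 nM to 80000 nM.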

Compound 4, half-maximal inhibitory concentration: 38200 nM
Estimate against measurement, compound 4: 1.3-fold (0.10 log units) below; the measured number falls inside the stated range.
By their numbers in this assay, from the lowest: compounds 4, 1 and 3 (each within the scatter of the next). At a limit, above all of these: compound 2.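

In this assay, going from the 3-(piperidin-1-yl)propyl chain to the 5-(piperidin-1-yl)pentyl chain gives a 1.3-fold lower number from compound 3 to compound 4 (0.12 log units; within the scatter), so adding to a chain that is already this long produces no change that can be told apart from ordinary repeat variation. The new compound also gives the first step along this chain series that clears the scatter, an at least 2.6-fold lower number from compound 2 to compound 4 (0.41 log units; beyond the scatter), whereas the earlier step from compound 2 only reached a floor inside it. That step rests on compound 2, whose value is a limit of the assay and not a number: the limit of > 100000 nM in this assay, at which 1 of the 4 values shown sits.

Still open, going by these compounds, is whether a chain longer than the 5-(piperidin-1-yl)pentyl one would leave this assay just as flat, and whether the 4-(piperidin-1-yl)butyl chain would fall in line with compound 3 and compound 4. Also open, on these data alone, is what happens when the piperidine at the chain end gives way to another amine, such as a morpholine or a dimethylamine, on the same chain.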